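The source may hold more compounds than are shown below. What is called first, only, known or untested is meant among the compounds shown, and "the series" means these compounds.

Measured in a functional assay on KB cells (Homo sapiens) for antiproliferative activity, read by MTT assay, with a stated time of 72 h; a higher number here means a weaker inhibitor, a lower number a stronger inhibitor:
- compound 1 `CCOC(=O)c1cc(-c2cc(OC)c(OC)c(OC)c2)c(-c2ccc(OC)c(O)c2)s1`: 1250 nM
- compound 2 `COc1ccc(-c2sccc2-c2cc(OC)c(OC)c(OC)c2)cc1`: 8880 nM
- compound 3 `COc1ccc(-c2sccc2-c2cc(OC)c(OC)c(OC)c2)cc1OCc1ccccc1`: > 100000 nM, a limit of the assay and not a number

Compound 3 has no number of its own and stands only at a limit, (the limit of > 100000 nM in this assay, at which 1 of the 3 values shown sits). Compound 4 `COc1ccc(-c2sccc2-c2cc(OC)c(OC)c(OC)c2)cc1O` differs from compound 3 by the change (hydrogen in place of benzyl on an oxygen on an aromatic ring), which is hydrogen in place of benzyl on an oxygen on an aromatic ring, or benzyloxy to hydroxy.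

Going by the values given here, the one measured step that bears on this is an at least 11-fold higher number from compound 2 to compound 3 (1.05 log units; beyond the scatter), a large one, made by benzyloxy in place of hydrogen on an aromatic carbon. Removing the benzyl should reverse much of that loss, so a large move to a lower number is expected in this assay. Compound 1, which also carries a hydroxy, gives 1250 nM, and this guides the expected level, though its ester is a further difference.

The expected change is an at least 50-fold lower number from compound 3 to compound 4 (1.69 log units; beyond the scatter). The estimate for compound 4 is 2000 nM, with an expected range from 200 nM to 15000 nM.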

Compound 4, half-maximal inhibitory concentration: 6270 nM
The estimate for compound 4 lay 3.1-fold (0.50 log units) below the measured number; low and high end bracket the measured number.
By their numbers in this assay, from the lowest: compound 1; then compounds 4 and 2 (each within the scatter of the next). At a limit, above all of these: compound 3.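

Compound 3 stands only at a limit of the assay, and not at a number: the limit of > 100000 nM in this assay, at which 1 of the 4 values shown sits. Even so, in this assay the change from benzyloxy to hydroxy gives an at least 15-fold lower number from compound 3 to compound 4 (1.20 log units; beyond the scatter), while the hydroxy cannot be told apart from hydrogen at this place, with a 1.4-fold lower number from compound 2 to compound 4 (0.15 log units; within the scatter), so the large loss goes with the benzyl and not with the oxygen left behind. The hydroxy alone therefore does not match the level of compound 1, and the ethoxycarbonyl marks the remaining difference, with a 5.0-fold higher number from compound 1 to compound 4 (0.70 log units; beyond the scatter).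

The compounds shown leave open whether a small group on this oxygen, such as methyl or ethyl, stays at the level of compound 4 or moves toward the limit. They also leave open whether a carboxylic acid or an amide in place of the ethoxycarbonyl would hold the level of compound 1.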